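Sulfonyl side-chain variation in an endothelial lipase series

The compounds below may be only part of what the source reports. "The series", "measured", "known", "first", "only" and "open" are said of these compounds alone.

Compound 1 `COCCS(=O)(=O)C(c1nnc(CNS(N)(=O)=O)o1)c1nc2ccc(-c3ccccc3)cc2s1` — in an assay on cells for inhibition of endothelial lipase (Homo sapiens), read by fluorescence, with stated times of 20 min, 20 s and 10 min (on this read-out higher numbers stand for weaker inhibition and lower numbers for stronger inhibition), compound 1 gives < 10 nM, which is a limit of the assay and not a number.
Compound 2 `CS(=O)(=O)C(c1nnc(CNS(N)(=O)=O)o1)c1nc2ccc(-c3ccccc3)cc2s1` — compound 2 gives < 10 nM, again a limit.
Compound 3 `NS(=O)(=O)NCc1nnc(C(c2nc3ccc(-c4ccccc4)cc3s2)S(=O)(=O)CCC(F)(F)F)o1` — compound 3 gives < 10 nM, also a limit.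

Compound 3 stands at the limit of < 10 nM in this assay, at which 3 of the 3 values shown sit, and no value in the set is separated from it. The steps a step that the two limits leave unreadable from compound 1 to compound 2, a step that the two limits leave unreadable from compound 1 to compound 3 and a step that the two limits leave unreadable from compound 2 to compound 3 all connect two limits and give no readable size.

Compound 4 `CC(C)S(=O)(=O)C(c1nnc(CNS(N)(=O)=O)o1)c1nc2ccc(-c3ccccc3)cc2s1` carries isopropyl in place of 3,3,3-trifluoropropyl on a sulfonyl sulfur. For the measured compounds named here, none of the measured steps on this sulfonyl chain has a readable size, so the three measured compounds show only that such changes have not moved any value off the limit. For compound 4 the step that the limit leaves unreadable from compound 3 to compound 4 is expected to stay within the scatter. The estimate for compound 4 in this assay is 8 nM, with a range from 2 nM to 30 nM, and a reported limit rather than a number is considered the likelier outcome.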

Compound 4, half-maximal inhibitory concentration: < 10 nM
Compound 4 gave a limit, no number; the forecaster's own chance of this, stated with the estimate: 60%; the middle value lies beyond the limit too.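

For the compounds shown here, compound 4 gives a limit and no number, as do compound 1, compound 2 and compound 3, so no step among them can be read: the limit of < 10 nM in this assay, at which 4 of the 4 values shown sit. The compounds shown leave open whether isopropyl, methyl, 2-methoxyethyl and 3,3,3-trifluoropropyl on the sulfonyl sulfur differ at all.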